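This account rests on a few compounds, and the source may have more. Where it says the series, first, only, none or still open, it means among the compounds named here.

Compound 2, `Cc1cc(=O)oc2cc(SCc3cccc(C(F)(F)F)c3)ccc12`, carries a trifluoromethyl group on a six-membered aromatic ring of carbon only, attached to the shared core. In a functional assay on DU-145 cells (Homo sapiens) for antiproliferative activity, read by sulforhodamine B assay, with a stated time of 72 h (a higher number here means a weaker inhibitor of growth, a lower number a stronger inhibitor of growth), compound 2 gives > 28500 nM, which is a limit of the assay rather than a number. Among the measured compounds shown here, compound 1, `Cc1cc(=O)oc2cc(SCc3ccncc3)ccc12`, is the only other compound measured so far; in this assay compound 1 gives > 35200 nM, again a limit. For the measured compounds named here, compound 2 thus stands at the limit of > 28500 nM in this assay, at which 1 of the 2 values shown sits, while the one further value shown sits at the limit of > 35200 nM in this assay, at which 1 of the 2 values shown sits, so no real ordering between the two can be read. Compound 3, `Cc1cc(=O)oc2cc(SCc3cccc(C#N)c3)ccc12`, differs from compound 2 by cyano in place of trifluoromethyl on an aromatic carbon. Going by the values given here, with no measured step to draw on, the expected change in this assay is none beyond the scatter, and the estimated step that the limit leaves unreadable from compound 2 to compound 3 expresses that. Compound 3 is therefore expected to give 40000 nM, within 15000 nM to 100000 nM, most likely reported once more only as a limit.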

Compound 3, concentration for 50% growth inhibition: > 32500 nM
Compound 3: no number, only a limit (the forecaster's own chance of this, stated with the estimate: 80%); the middle value lies beyond the limit too.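

Compound 2 and compound 3 are both reported only as limits, so no step can be read for cyano in place of trifluoromethyl. The compounds shown leave open how strongly compound 1, compound 2 or compound 3 inhibits growth in this assay, and whether any group on this core gives a measurable value.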